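This account rests on a few compounds, and the source may have more. Where it says the series, first, only, none or still open, it means among the compounds named here.

Series notes, three measured amides and one open position.

Compound 1 `C=CCNC(=O)/C(C)=C(/C)c1ccc(Cl)cc1` and compound 2 `C=CCNC(=O)/C(C)=C(\C)c1ccc(Br)cc1` carry the allyl amide; compound 3 `C/C(C(=O)NC1CC1)=C(/C)c1ccc(F)cc1` carries the cyclopropyl amide. In a toxicity assay on the whole organism (strain Icem-CET (SPF Caw)) for cytotoxicity, with Mus musculus as the target (a lower number here means that less compound is needed, a higher number that more compound is needed for the effect), compound 1 gives 400 mg/kg and compound 2 gives 500 mg/kg. In this assay compound 3 gives 70 mg/kg, the lowest number of the three, and its distance to both compound 1 and compound 2 lies beyond the scatter, so compound 3 needs the least compound for the half-maximal effect. For the measured compounds named here, no pair of measured compounds differs in a single place, so no isolated step is available.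

Compound 4 `C/C(C(=O)NC1CC1)=C(/C)c1ccccc1` has not been measured. Relative to compound 3 the change is hydrogen in place of fluoro on an aromatic carbon. Going by the values given here, no measured pair shows what removal of a ring halogen does in this assay, and compound 1 and compound 2 differ from compound 3 in more than the halogen, so they give no direct guide. The expectation is a step from compound 3 to compound 4 of a 1.4-fold higher number from compound 3 to compound 4 (0.15 log units; within the scatter), upward if anything, but not clearly beyond the scatter. Compound 4 is estimated at 100 mg/kg, with a range from 40 mg/kg to 250 mg/kg.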

Compound 4, dose for half-maximal effect: 150 mg/kg
For compound 4 the middle estimate is 1.5-fold (0.18 log units) below the measured one, and the stated range covers the measured number.
By their numbers in this assay, from the lowest: compound 3; then compound 4; then compounds 1 and 2 (each within the scatter of the next).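

In this assay the series now has its first step at a single place: hydrogen in place of fluoro on an aromatic carbon, para to a large group, gives a 2.1-fold higher number from compound 3 to compound 4 (0.33 log units; beyond the scatter). For the compounds shown here, the position is therefore not silent, since with the cyclopropyl amide and the rest of the core held constant, the ring substituent alone moves the number by a modest step, and the fluoro compound is the one that needs less compound for the half-maximal effect; compound 1 and compound 2 could not show this, as each differs from compound 3 in more than the halogen. Nothing at hand explains the direction of this step, and no measurement bears on its cause.

Still open, from the compounds shown here alone, is how other groups at this place would read on the cyclopropyl amide, for example chloro and bromo, which appear here only with the allyl amide, or a methoxy group or an amine. Also open, going by these compounds, is whether the same exchange of fluoro for hydrogen gives a step of similar size and direction on the allyl amide, and how far the amide itself contributes to the numbers.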